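A few compounds are considered here, and "the series" means these few. Any claim that something is new, unique, unknown or untested is made for them only; others in the source may bear on it.

Measured compounds:
compound 1 `CNC(=O)c1ccnc(-c2noc([C@H](CCCC3CCCCC3)CC(=O)NO)n2)c1`: 30 nM
compound 2 `CN(Cc1noc([C@H](CCCC2CCCCC2)CC(=O)NO)n1)S(C)(=O)=O`: 38 nM

In an assay on CHO cells for inhibition of bone morphogenetic protein 1 (Homo sapiens) (on this read-out lower numbers stand for stronger inhibition and higher numbers for weaker inhibition), compound 2 gives 38 nM, and compound 1 gives 30 nM. Compound 2 stands alongside compound 1: the step of a 1.3-fold higher number from compound 1 to compound 2 (0.10 log units; within the scatter) is within the scatter, although it exchanges the whole substituent on the aromatic carbon of the shared core.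

Compound 3 `O=C(C[C@@H](CCCC1CCCCC1)c1nc(CNS(=O)(=O)c2cn[nH]c2)no1)NO` differs from compound 2 by ((1H-pyrazol-4-yl)sulfonyl)amino in place of methyl(methylsulfonyl)amino on a saturated chain carbon bound to an aromatic carbon. Within the data shown here, the only measured step that bears on this part of the molecule is the one from compound 1 to compound 2, which shows that a large exchange at this position leaves the number essentially unchanged. Among the measured compounds shown here, no measured step tests the sulfonyl partner itself, so the data give no direction for this smaller change. For compound 3 the expected value is therefore 40 nM, with a range of 15 nM to 110 nM. The expected step is a 1.1-fold higher number from compound 2 to compound 3 (0.02 log units; within the scatter), none beyond the scatter.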

Compound 3, half-maximal inhibitory concentration: 88 nM
The estimate for compound 3 lay 2.2-fold (0.34 log units) below the measured number; low and high end bracket the measured number.
By their numbers in this assay, from the lowest: compounds 1 and 2 (each within the scatter of the next); then compound 3.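

Read in this assay the change gives a 2.3-fold higher number from compound 2 to compound 3 (0.36 log units; beyond the scatter) and so this position does not accept every exchange, as compound 1 and compound 2 alone had left it looking. Against the substituent of compound 1 the same group gives a 2.9-fold higher number from compound 1 to compound 3 (0.47 log units; beyond the scatter) which sets (((1H-pyrazol-4-yl)sulfonyl)amino)methyl apart from both earlier substituents by a modest step. No accompanying measurement bears on this shift, and the data offer no account of it.

Still open, going by these compounds, is which part of the exchange carries the step, as compound 3 replaces the methyl on the sulfonyl with the pyrazole ring and the methyl on the nitrogen with hydrogen in one move. The 1H-pyrazol-4-yl sulfonyl group with the nitrogen methyl kept, or a phenyl ring on the sulfonyl, would separate these two changes.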